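Bromophenyl Ketone in Place of Trifluoromethylphenyl Ketone

This account rests on a few compounds, and the source may have more. Where it says the series, first, only, none or still open, it means among the compounds named here.

Three compounds have been measured in a functional assay on A549 cells (Homo sapiens) for cytotoxicity, read by MTT assay, with a stated time of 48 h; a lower number here means a stronger inhibitor, a higher number a weaker inhibitor:
Compound 1 `COc1ccc(C(=O)C2Sc3nnc(-c4cc(OC)c(OC)c(OC)c4)n3NC2c2ccco2)cc1` gives a limit of the assay, > 100000 nM.
Compound 2 `COc1cc(-c2nnc3n2NC(c2ccco2)C(C(=O)c2ccc(O)cc2)S3)cc(OC)c1OC` gives 93400 nM.
Compound 3 `COc1cc(-c2nnc3n2NC(c2ccco2)C(C(=O)c2ccc(C(F)(F)F)cc2)S3)cc(OC)c1OC` gives 37200 nM.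

Compound 3 holds the lowest of the two numbers; its nearest neighbour is compound 2, with a 2.5-fold lower number from compound 2 to compound 3 (0.40 log units; beyond the scatter). Compound 1 sits at the limit (the limit of > 100000 nM in this assay, at which 1 of the 3 values shown sits), and from it to compound 3 the step was an at least 2.6-fold lower number from compound 1 to compound 3 (0.42 log units; beyond the scatter), while an at least 1.0-fold lower number from compound 1 to compound 2 (0.02 log units; that floor lies within the scatter).

Compound 4 `COc1cc(-c2nnc3n2NC(c2ccco2)C(C(=O)c2cccc(Br)c2)S3)cc(OC)c1OC` differs from compound 3 by 3-bromophenyl in place of 4-(trifluoromethyl)phenyl on a carbonyl carbon. Both measured steps into compound 3 exchanged the group on the same carbonyl carbon and each gave a modest lowering, but neither swapped one halogen-bearing phenyl ring for another, so they bear only loosely on this change. Compound 4 is therefore expected to stay close to compound 3, with no step beyond the scatter anticipated; the estimate for compound 4 in this assay is 45000 nM, within 20000 nM to 100000 nM. This estimate means an expected step of a 1.2-fold higher number from compound 3 to compound 4 (0.08 log units; within the scatter).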

Compound 4, half-maximal inhibitory concentration: 36900 nM
Compound 4: the middle estimate sits 1.2-fold (0.09 log units) above what was measured, within the range that was stated.
By their numbers in this assay, from the lowest: compounds 4 and 3 (each within the scatter of the next); then compound 2. At a limit, above all of these: compound 1.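

In this assay, 3-bromophenyl in place of 4-(trifluoromethyl)phenyl on the carbonyl carbon gave a 1.0-fold lower number from compound 3 to compound 4 (0.00 log units; within the scatter), so this position now holds two different halogen-bearing phenyl rings whose values lie within the scatter of each other. The gain over the hydroxy-bearing ring also appears with this second ring, as a 2.5-fold lower number from compound 2 to compound 4 (0.40 log units; beyond the scatter). Against the methoxy-bearing ring the result is only a floor, an at least 2.7-fold lower number from compound 1 to compound 4 (0.43 log units; beyond the scatter), since compound 1 gives a limit and not a number: the limit of > 100000 nM in this assay, at which 1 of the 4 values shown sits.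

The compounds shown leave open whether 4-bromophenyl would read like 3-bromophenyl, and whether a phenyl ring carrying an amine or a carboxylic acid would hold this level. They also cannot tell how a change elsewhere on the shared core would act, as the core stays the same throughout.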